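What one methoxy group may do to compound 2

This account rests on a few compounds, and the source may have more. Where it says the series, first, only, none or still open, it means among the compounds named here.

So far, only two compounds have been measured in a physicochemical assay for lipophilicity, at pH 7.4; on this read-out higher numbers stand for higher lipophilicity and lower numbers for lower lipophilicity. Compound 2 `C[C@H]1C(=O)N(C)C=Cc2ccccc21` gives 4.3, the higher of the two numbers. Compound 1 `COc1cc2c(cc1OC)[C@@H](C)C(=O)N(C)C=C2`, which also bears methoxy, gives 3.4, and the gap between the two lies beyond the scatter.

Compound 3 `COc1ccc2c(c1)C=CN(C)C(=O)[C@@H]2C` has not yet been measured. It differs from compound 2 in one place: methoxy in place of hydrogen on an aromatic carbon. In words, methoxy stands in place of hydrogen on an aromatic carbon.

Among the measured compounds shown here, no pair of measured compounds shows this single change on its own, so the size of the step can only be judged indirectly. For the measured compounds named here, the one guide is compound 1 at 3.4, a methoxy-bearing compound that sits lower on this assay than compound 2 at 4.3. A modest fall is therefore expected, with the estimated change being a number 0.40 log units lower from compound 2 to compound 3 (beyond the scatter). Compound 3 is estimated at 3.9, with an expected range of 3.5 to 4.3.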

Compound 3, distribution coefficient: 4.3
For compound 3 the middle estimate is 0.40 log units below the measured one; the measured number falls inside the stated range.
By their numbers in this assay, from the lowest: compound 1; then compounds 2 and 3 (each within the scatter of the next).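

In this assay, methoxy in place of hydrogen on this aromatic carbon, meta to a fused ring and para to a fused ring, gives no change at the digits printed from compound 2 to compound 3 (within the scatter), so at this position the two compounds cannot be told apart on this read-out. The lower number of compound 1 therefore does not go with this methoxy, which compound 1 and compound 3 share; it goes with the second methoxy of compound 1, since hydrogen in place of that group gives a number 0.90 log units higher from compound 1 to compound 3 (beyond the scatter). Two methoxy groups on the same core thus give steps of different size depending on the aromatic carbon they occupy, although nothing available explains that difference.

From the compounds shown here alone, it remains open whether a different group on this same aromatic carbon, such as an amine, a carboxylic acid or a longer chain like ethoxy, would give a step beyond the scatter. Also open, going by these compounds, is whether the second methoxy would give a step of similar size on a core that lacks the methoxy of compound 3.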